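The source may hold more compounds than are shown below. What is called first, only, known or untested is meant among the compounds shown, and "the series" means these compounds.

In a functional assay on B16-F10 cells (Mus musculus) for antiproliferative activity, read by colorimetric assay and MTT assay, with a stated time of 48 h (a lower number here means a stronger inhibitor, a higher number a weaker inhibitor), compound 1 `O=C(NS(=O)(=O)c1ccc(F)cc1)c1ccncc1` gives 13800 nM and compound 2 `O=C(NS(=O)(=O)c1ccc(Cl)cc1)c1ccncc1` gives 12400 nM, so compound 2 stands within the scatter of compound 1. Compound 3 `O=C(NS(=O)(=O)c1ccc(Br)cc1)c1ccncc1` differs from compound 2 by bromo in place of chloro on an aromatic carbon. Going by the values given here, the only measured step bearing on this change is a 1.1-fold lower number from compound 1 to compound 2 (0.05 log units; within the scatter), with chloro in place of fluoro on an aromatic carbon. This single step gives no basis for expecting a change beyond the scatter in this assay. For compound 3 the estimated value is 11500 nM, with an expected range of 6500 nM to 20000 nM. The expected step is a 1.1-fold lower number from compound 2 to compound 3 (0.03 log units; within the scatter).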

Compound 3, half-maximal inhibitory concentration: 8800 nM
Estimate against measurement, compound 3: 1.3-fold (0.12 log units) above; the measured number falls inside the stated range.
By their numbers in this assay, from the lowest: compounds 3, 2 and 1 (each within the scatter of the next).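

In this assay bromo in place of chloro on an aromatic carbon gives a 1.4-fold lower number from compound 2 to compound 3 (0.15 log units; within the scatter) and bromo in place of fluoro gives a 1.6-fold lower number from compound 1 to compound 3 (0.20 log units; within the scatter) as the second reading at this place. Going by these compounds alone, with three halogens now compared, para to a large group, no pair of them separates beyond the scatter. No evidence at hand bears on these numbers. Going by these compounds, whether an amine, a carboxylic acid or a methoxy group at this place would move the number beyond the scatter stays open. Changes elsewhere on the shared core also stay open.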